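This account rests on a few compounds, and the source may have more. Where it says the series, first, only, none or still open, it means among the compounds named here.

Compound 3 `C=CC1=C(C(=O)NC2CCCCC2)C(c2ccc(OC)cc2)OC1` carries a cyclohexyl amide on the shared core. In a functional assay on A549 cells (Homo sapiens) for cytotoxicity, read by MTT assay, with a stated time of 24 h (a higher number here means a weaker inhibitor, a lower number a stronger inhibitor), compound 3 gives > 100000 nM, which is a limit of the assay and not a number. Compound 1 `C=CC1=C(C(=O)NCc2ccc(Cl)cc2)C(c2ccc(F)cc2)OC1`, with a 4-chlorobenzyl amide on a core bearing 4-fluorophenyl, gives > 100000 nM in this assay, again a limit. Going by the values given here, compound 2 `C=CC1=C(C(=O)Nc2ccc(OCC)cc2)C(c2ccc(OC)cc2)OC1` is the only one with a measured number: in this assay compound 2 gives 17600 nM. Among the compounds with values here, the sole measured step at the amide nitrogen, an at least 5.6-fold higher number from compound 2 to compound 3 (0.75 log units; beyond the scatter), runs from that number up to the limit, as the limit of > 100000 nM in this assay, at which 2 of the 3 values shown sit, records. Compound 4 `C=CC1=C(C(=O)NCc2ccc(Cl)cc2)C(c2ccc(OC)cc2)OC1` differs from compound 3 by 4-chlorobenzyl in place of cyclohexyl on an amide-type nitrogen. Within the data shown here, no measured step covers cyclohexyl against 4-chlorobenzyl, and compound 1, which carries the same 4-chlorobenzyl amide, sits at the limit. The step of a number no higher from compound 3 to compound 4 (the limit leaves the size open) is therefore expected to stay within the scatter. Compound 4 is expected at 100000 nM, with a range from 30000 nM to 300000 nM, most likely reported as a limit once more.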

Compound 4, half-maximal inhibitory concentration: > 100000 nM
Compound 4 ended at the assay's limit; the forecaster's own chance of this, stated with the estimate: 70%; the middle value sits exactly at the limit.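

On the amide-type nitrogen, 4-chlorobenzyl in place of 4-ethoxyphenyl gives an at least 5.6-fold higher number from compound 2 to compound 4 (0.75 log units; beyond the scatter) in this assay, so a second group besides cyclohexyl loses the measurable number that the 4-ethoxyphenyl amide gives. The steps from the cyclohexyl amide to the 4-chlorobenzyl amide and from fluoro to methoxy on an aromatic carbon cannot be read, as both ends of each are limits of the assay and not numbers. Of the amides shown, only the 4-ethoxyphenyl amide of compound 2 gives a number, and the rest of the series sits at one ceiling: the limit of > 100000 nM in this assay, at which 3 of the 4 values shown sit.

On these data alone, whether the number of compound 2 rests on the phenyl ring or on its ethoxy group stays open. An unsubstituted phenyl or a phenyl carrying a carboxylic acid on the amide-type nitrogen would separate the two.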